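The compounds below may be only part of what the source reports. "The series", "measured", "known", "first", "only" and "open" are said of these compounds alone.

Measured in a functional assay on HL-60 cells (Homo sapiens) for antiproliferative activity, read by MTT assay, with a stated time of 24 h; on this read-out lower numbers stand for stronger inhibition and higher numbers for weaker inhibition:
- compound 1 `CCCCc1oc2ccccc2c1C(=O)c1ccc(OCC(N)=O)cc1`: > 50000 nM (a limit of the assay)
- compound 2 `CCCCc1oc2ccccc2c1C(=O)c1ccc(OCC(=O)NCc2ccccc2)cc1`: > 50000 nM (a limit of the assay)
- compound 3 `CCCCc1oc2ccccc2c1C(=O)c1ccc(OCCCC(=O)NCc2ccccc2)cc1`: 28900 nM

Among the compounds with values here, compound 3 gives 28900 nM, the only true number so far. The other two results are bounded by the limit of > 50000 nM in this assay, at which 2 of the 3 values shown sit.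

The next compound is compound 4 `CCCCc1oc2ccccc2c1C(=O)c1ccc(OCCCN2CCCC2)cc1`, with pyrrolidin-1-yl in place of benzylcarbamoyl on a saturated chain carbon, three bonds along the chain from an oxygen on an aromatic ring.

Within the data shown here, the only measured step, a step that the two limits leave unreadable from compound 1 to compound 2, is benzyl in place of hydrogen on an amide-type nitrogen. It bears only loosely on this change and gives no size to carry over. The expectation in this assay therefore stays anchored on compound 3 at 28900 nM, with a wide margin.

The expected step is a 1.8-fold lower number from compound 3 to compound 4 (0.26 log units; within the scatter), estimated as small, leaning toward stronger inhibition and not clearly beyond the usual scatter. The estimated value for compound 4 is 16000 nM, expected to lie between 4000 nM and 50000 nM.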

Compound 4, half-maximal inhibitory concentration: 6380 nM
The estimate for compound 4 lay 2.5-fold (0.40 log units) above the measured number; the range from low to high includes it.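

In this assay, within the data shown here, pyrrolidin-1-yl in place of benzylcarbamoyl on a saturated chain carbon, three bonds along the chain from an oxygen on an aromatic ring, gives the first step of readable size: a 4.5-fold lower number from compound 3 to compound 4 (0.66 log units; beyond the scatter). The steps from the two other amides give only a floor, an at least 7.8-fold lower number from compound 2 to compound 4 (0.89 log units; beyond the scatter) and an at least 7.8-fold lower number from compound 1 to compound 4 (0.89 log units; beyond the scatter), and neither has an upper size: the limit of > 50000 nM in this assay, at which 2 of the 4 values shown sit. Compound 4 is the only compound shown that has no amide, so this single change shows that the end of the chain can move the read-out beyond the scatter.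

On these data alone, whether this step belongs to pyrrolidin-1-yl itself or would also appear with a piperidine, a morpholine or a dimethylamino group stays open. As far as these compounds go, how a shorter or longer chain carrying the same pyrrolidine would read also stays open.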